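The source may report more compounds than this note shows. Statements on the series, on what has been measured and on what is new or still open speak of the compounds shown alone.

Measured compounds in an ADME assay on GES1 cells (Homo sapiens) for cytotoxicity, read by MTT assay, with a stated time of 24 h; on this read-out higher numbers stand for lower toxicity in this test and lower numbers for higher toxicity in this test:
compound 1, `O=c1[nH]cc(S(=O)(=O)Nc2ccc(-c3cn(-c4ccccc4)nn3)cc2)c(=O)[nH]1` — "not toxic" (no number reported)
compound 2, `Cc1ccc(-n2cc(-c3ccc(NS(=O)(=O)c4c[nH]c(=O)[nH]c4=O)cc3)nn2)cc1` — "not toxic" (no number reported)
compound 3, `O=c1[nH]cc(S(=O)(=O)Nc2ccc(-c3cn(-c4ccccc4F)nn3)cc2)c(=O)[nH]1` — > 100000 nM

Compound 1 and compound 2 are each reported without a number, only with the statement that they are not toxic in this assay. For compound 3 the reported value is a limit of the assay and not a number, namely > 100000 nM. Compound 3 therefore stands at the limit of > 100000 nM in this assay, at which 1 of the 3 values shown sits, and it is the only one of the three for which any figure at all is given. Among the measured compounds shown here, no step between two measured compounds can be drawn from these entries, so there is nothing to calibrate a change against.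

Compound 4, `O=c1[nH]cc(S(=O)(=O)Nc2ccc(-c3cn(-c4cccc(F)c4)nn3)cc2)c(=O)[nH]1`, is the compound still to be measured. It differs from compound 3 by one change: 3-fluorophenyl in place of 2-fluorophenyl on an aromatic nitrogen. For the measured compounds named here, with no measured step to lean on, the expectation is that this change produces no step beyond the scatter in this assay, in either direction, so that the step that the limit leaves unreadable from compound 3 to compound 4 is estimated as essentially flat. Compound 4 is accordingly expected to give about 150000 nM in this assay, with an estimated range from 60000 nM to 400000 nM, and the most likely outcome is that the assay once more reports only a limit.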

Compound 4, half-maximal cytotoxic concentration: "not toxic" (no number reported)
No number was reported for compound 4, and the estimate cannot be compared.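

In this assay, among the compounds shown here, compound 4 is reported as "not toxic" (no number reported) and so gives no number, which means no step from compound 3 to compound 4 can be read. Compound 3 holds only a limit of the assay: the limit of > 100000 nM in this assay, at which 1 of the 4 values shown sits. The compounds shown leave open whether 2-fluorophenyl and 3-fluorophenyl differ at all in this assay and at what concentration, if any, any of these compounds becomes toxic.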